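Swapping Iodo for Amino on Compound 2

The source may report more compounds than this note shows. Statements on the series, on what has been measured and on what is new or still open speak of the compounds shown alone.

- Compound 1 `COc1ccc(C(=O)/C=C/c2cc(=O)[nH]c(=O)n2COCCO)cc1` gives 33500 nM in cell tests
- Compound 2 `CC(=O)OCCOCn1cnc2c(Cl)nc(I)nc21` gives 8600 nM in cell tests

In an ADME assay on L1210/0 cells (Mus musculus) for cytotoxicity, with a stated time of 48 h (on this read-out lower numbers stand for stronger inhibition and higher numbers for weaker inhibition), compound 2 holds the lower number of the two, and its gap to compound 1 lies beyond the scatter. Compound 3 `CC(=O)OCCOCn1cnc2c(Cl)nc(N)nc21` differs from compound 2 in one place: amino in place of iodo on an aromatic carbon with amino in place of iodo on an aromatic carbon. Within the data shown here, no measured pair shows what this swap does, so any forecast stays loose. The expected change, a 2.3-fold higher number from compound 2 to compound 3 (0.37 log units; beyond the scatter), is a modest rise in the number, meaning somewhat weaker inhibition. The estimate for compound 3 is 20000 nM with 6000 nM to 60000 nM as its expected range.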

Compound 3, half-maximal inhibitory concentration: > 200000 nM
Compound 3: a limit, no number (the forecaster's own chance of this, stated with the estimate: 15%); middle value at least 10-fold (1.00 log units) away from the limit.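

Among these compounds, the group on this aromatic carbon, between two ring nitrogen atoms, matters far more than the earlier compounds could show: amino in place of iodo gives an at least 23-fold higher number from compound 2 to compound 3 (1.36 log units; beyond the scatter). Here iodo goes with much stronger inhibition than amino. Compound 3 has a limit rather than a number, so the full size of this step stays unknown: the limit of > 200000 nM in this assay, at which 1 of the 3 values shown sits.

One pair cannot separate what losing iodo does from what gaining amino does. On these data alone, whether bromo, a methylamino group or plain hydrogen at this place would behave like iodo or like amino remains open.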